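The compounds below may be only part of what the source reports. "The series", "measured", "known", "first", "only" and "open" are said of these compounds alone.

Measured so far in a functional assay on cells (Mus musculus) for cytotoxicity, read by MTT assay, with a stated time of 72 h; a lower number here means a stronger inhibitor, a higher number a weaker inhibitor:
compound 1, `COc1ccc(C(=O)CCc2c(OC)cc(O)cc2OC)cc1`: 68100 nM
compound 2, `COc1ccc(CCC(=O)c2ccc(O)cc2)c(O)c1`: 81400 nM
compound 3, `O=C(CCc1ccc(O)cc1O)c1ccc(O)cc1`: for compound 3 the assay gave only a limit, > 100000 nM.

The numbers for compound 1 and compound 2 lie within the usual scatter of each other, so no order between them can be read. The difference between the two cores is not broken down here. From compound 2 to compound 3 the change was hydrogen in place of methyl on an oxygen on an aromatic ring, and this gave an at least 1.2-fold higher number from compound 2 to compound 3 (0.08 log units; that floor lies within the scatter), the step being open-ended because of the limit of > 100000 nM in this assay, at which 1 of the 3 values shown sits.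

Compound 4, `COc1cc(O)cc(OC)c1CCC(=O)c1ccc(O)cc1`, arises from compound 1 by the same change, (hydrogen in place of methyl on an oxygen on an aromatic ring). Going by that earlier step, the estimate for compound 4 is a step of a 1.3-fold higher number from compound 1 to compound 4 (0.12 log units; within the scatter), a weakening within or near the scatter. The number expected for compound 4 is therefore 90000 nM, between 45000 nM and 180000 nM.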

Compound 4, half-maximal inhibitory concentration: 40200 nM
For compound 4 the middle estimate is 2.2-fold (0.35 log units) above the measured one; measured number below the stated range.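

In this assay, going from methoxy to hydroxy gave a 1.7-fold lower number from compound 1 to compound 4 (0.23 log units; within the scatter), so on this core the change cannot be told apart from ordinary variation between repeated measurements. Set beside the same change on the other core, the comparison stays unsettled: the same change on two cores in this assay, an at least 1.2-fold higher number (0.08 log units; that floor lies within the scatter) from compound 2 to compound 3 and a 1.7-fold lower number (0.23 log units; within the scatter) from compound 1 to compound 4; the limit leaves it open whether they differ. Neither a shared effect nor a different one is shown, and compound 3 stands only as a limit: the limit of > 100000 nM in this assay, at which 1 of the 4 values shown sits.

The compounds shown carry only methoxy or hydroxy at the places that change. They leave open whether a different group there, such as an ethoxy group or an amine, would give a step beyond the scatter.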